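Adding an Amino Group on a Second, Rearranged Core

This account rests on a few compounds, and the source may have more. Where it says the series, first, only, none or still open, it means among the compounds named here.

Three compounds have been measured in a functional assay on OVCAR-4 cells (Homo sapiens) for cytotoxicity, read by sulforhodamine B assay, with a stated time of 48 h; a lower number here means a stronger inhibitor of growth, a higher number a weaker inhibitor of growth:
compound 1 `ClCc1ccc(Cn2cnc3c(Cl)ncnc32)cc1` gives 6600 nM;
compound 2 `Nc1nc(Cl)c2ncn(Cc3ccc(CCl)cc3)c2n1` gives 30200 nM;
compound 3 `ClCc1ccccc1Cn1cnc2c(Cl)ncnc21` gives 12300 nM.

Compound 1 and compound 3 are built from the same atoms joined differently; the difference between the two cores is not broken down here. Compound 2 differs from compound 1 by amino in place of hydrogen on an aromatic carbon, and that change gave a 4.6-fold higher number from compound 1 to compound 2 (0.66 log units; beyond the scatter). Compound 3 sits near compound 1, within the scatter, while compound 2 is beyond it.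

Compound 4 `Nc1nc(Cl)c2ncn(Cc3ccccc3CCl)c2n1` differs from compound 3 by amino in place of hydrogen on an aromatic carbon, the same change as before, at the same kind of place. Because a 4.6-fold higher number from compound 1 to compound 2 (0.66 log units; beyond the scatter) was modest, a step of similar size is expected, that is a 4.1-fold higher number from compound 3 to compound 4 (0.61 log units; beyond the scatter). Compound 4 is therefore estimated at 50000 nM, most likely between 20000 nM and 120000 nM.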

Compound 4, concentration for total growth inhibition: 6460 nM
Compound 4: middle estimate off by 7.7-fold (0.89 log units), on the high side, and the stated range ends above it.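

In this assay, amino in place of hydrogen on the core of compound 3 gave a 1.9-fold lower number from compound 3 to compound 4 (0.28 log units; within the scatter), so the clear rise in the number seen on the core of compound 1 did not recur. The two steps differ: the same change on two cores in this assay, a 4.6-fold higher number (0.66 log units; beyond the scatter) from compound 1 to compound 2 and a 1.9-fold lower number (0.28 log units; within the scatter) from compound 3 to compound 4, 8.7-fold (0.94 log units) apart, beyond the scatter of two such steps. This shows that, in these two pairs, the size of the step on one core did not predict the step on the other, but it does not show why the cores part ways or what the change would do on any further core.

The compounds shown leave open whether a methylamino group or a hydroxyl group on that same aromatic carbon would also give different steps on the two cores.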